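The source may report more compounds than this note shows. Statements on the series, on what has been measured and on what is new or still open speak of the compounds shown alone.

Measured compounds:
compound 1 `CC(C)(C)c1cc(NC(=O)Nc2cccc(Oc3ccnc4[nH]c(=O)cnc34)c2)n(-c2ccccc2)n1`: 6%
compound 2 `Cc1nc2c(Oc3ccc(NC(=O)Nc4cc(C(F)(F)F)ccc4F)c4ccccc34)ccnc2[nH]c1=O`: 4%
compound 3 `Cc1ccc(-n2nc(C(C)(C)C)cc2NC(=O)Nc2ccc(Oc3ccnc4[nH]c(=O)cnc34)cc2)cc1`: 17%

All three were run in an in vivo ADME assay on the whole organism (strain C57BL/cAnNCrl) for pharmacokinetics, with Mus musculus as the target, at a dose of 10 mg/kg by the oral route; a higher number here means that a larger share of the oral dose reaches the circulation, a lower number that a smaller share of the oral dose reaches the circulation. On these numbers compound 1 stands second highest of three: compound 2 lies within the scatter of it, while compound 3 lies beyond the scatter, on the higher side.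

Compound 4 `Cc1ccc(-n2nc(C(C)(C)C)cc2NC(=O)Nc2cccc(Oc3ccnc4[nH]c(=O)cnc34)c2)cc1` is compound 1 with one change, (methyl in place of hydrogen on an aromatic carbon), a methyl in place of hydrogen on an aromatic carbon. Within the data shown here, no pair of measured compounds differs in this place alone. Compound 3 carries the same 4-methylphenyl but differs from compound 1 elsewhere as well, so the values of compound 1 and compound 3 show only that this two-part difference ends beyond the scatter.

For compound 4 a small step upward, not beyond the scatter, is expected in this assay: a number 4 percentage points higher from compound 1 to compound 4 (within the scatter). The estimate for compound 4 in this assay is 10%, with a range from 3% to 22%.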

Compound 4, oral bioavailability: 27%
Beside the measured number, compound 4's estimate is 17 percentage points below it, and the stated range ends below it.
By their numbers in this assay, from the lowest: compounds 2 and 1 (each within the scatter of the next); then compounds 3 and 4 (each within the scatter of the next).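

In this assay, the change from phenyl to 4-methylphenyl gives a number 21 percentage points higher from compound 1 to compound 4 (beyond the scatter) and so lies beyond the scatter. Among these compounds, this is the first reading of this position on its own, since the earlier compounds offered only a two-part difference. A single methyl on this aromatic carbon, para to a large group, is thus sufficient for a step of this size. Nothing measured here accounts for the rise. From the compounds shown here alone, whether methoxy or chlorine at the same place gives a similar step remains open, as does whether the methyl gives this step on other compounds.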